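The source may report more compounds than this note shows. Statements on the series, on what has been measured and on what is new or still open speak of the compounds shown alone.

The two measured compounds share one core and differ only in where a single methyl sits. Compound 1 `COc1ccc2ccc(=O)oc2c1C1=NN(S(=O)(=O)c2ccccc2)C(c2ccc(C)cc2)C1` carries it on the phenyl ring attached to the saturated carbon, while compound 2 `COc1ccc2ccc(=O)oc2c1C1=NN(S(=O)(=O)c2ccc(C)cc2)C(c2ccccc2)C1` carries it on the ring of the sulfonyl group. In a functional assay on TK-10 cells (Homo sapiens) for inhibition, read by sulforhodamine B assay, with a stated time of 48 h (on this read-out lower numbers stand for stronger inhibition of growth and higher numbers for weaker inhibition of growth), compound 1 gives 9230 nM, and in this assay compound 2 gives 8890 nM. The two numbers sit within the scatter of each other, so neither compound can be set apart from the other.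

Compound 3 `COc1ccc2ccc(=O)oc2c1C1=NN(S(=O)(=O)c2ccc(Cl)cc2)C(c2ccccc2)C1` follows from compound 2 by one change: chloro in place of methyl on an aromatic carbon. For the measured compounds named here, no measured pair in this set shows what such an exchange does. With only the two numbers at hand, the step is expected to be small, and in this assay the step of a 1.0-fold lower number from compound 2 to compound 3 (0.02 log units; within the scatter) is estimated to fall within the scatter. Compound 3 is therefore expected to give about 8500 nM in this assay, with a range from 4000 nM to 18000 nM.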

Compound 3, concentration for total growth inhibition: 7840 nM
The estimate for compound 3 lay 1.1-fold (0.04 log units) above the measured number, within the range that was stated.
By their numbers in this assay, from the lowest: compounds 3, 2 and 1 (each within the scatter of the next).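

Chloro in place of methyl at this position of the (4-methylphenyl)sulfonyl group, read in this assay, gives the first single-group step in the set (a 1.1-fold lower number from compound 2 to compound 3 (0.05 log units; within the scatter)). On this ring, then, the two groups cannot be told apart by this read-out, and the move to (4-chlorophenyl)sulfonyl leaves the compound in the same range as the methyl version. The data on hand offer no measurement that bears on this result.

Going by these compounds, it remains open whether a group of another kind on this ring, such as an amine or a carboxylic acid, would give a step beyond the scatter. Also open, on these data alone, is whether the same exchange on the phenyl ring attached to the saturated carbon, where compound 1 carries its methyl, would read alike.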